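Ring size at the hydroxylated side-chain terminus

A few compounds are considered here, and "the series" means these few. Any claim that something is new, unique, unknown or untested is made for them only; others in the source may bear on it.

Measured so far:
compound 1, `COC(=O)CC/C=C\CC[C@H]1C(=O)C[C@@H](O)[C@@H]1/C=C/C[C@@](C)(O)/C=C/C1=CCCC1` — in a functional assay on the whole organism with Rattus norvegicus as the target (a lower number here means that less compound is needed, a higher number that more compound is needed for the effect), compound 1 shows only the limit > 3.16 mg/kg.
compound 2, `COC(=O)CC/C=C\CC[C@H]1C(=O)C[C@@H](O)[C@@H]1/C=C/CC(C)(O)CCC1CCCC1` — in this assay compound 2 gives 1.31 mg/kg.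
compound 3, `CCCCC(C)(O)C/C=C/[C@H]1[C@H](O)CC(=O)[C@@H]1CC/C=C\CCC(=O)OC` — in this assay compound 3 gives 0.049 mg/kg.

Compound 1 thus stands at the limit (the limit of > 3.16 mg/kg in this assay, at which 1 of the 3 values shown sits), with no number of its own. Compound 4, `COC(=O)CC/C=C\CC[C@H]1C(=O)C[C@@H](O)[C@@H]1/C=C/C[C@@](C)(O)/C=C/C1=CCCCC1`, differs from it as follows: cyclohex-1-en-1-yl in place of cyclopent-1-en-1-yl on a double-bonded chain carbon bound to a double-bonded chain carbon. Going by the values given here, no measured step alters ring size alone. The steps of an at least 2.4-fold lower number from compound 1 to compound 2 (0.38 log units; beyond the scatter) and an at least 64-fold lower number from compound 1 to compound 3 (1.80 log units; beyond the scatter) show that removing the cyclopentenyl unit, or shortening to an open chain, lowers the number strongly, and a 27-fold lower number from compound 2 to compound 3 (1.43 log units; beyond the scatter) points the same way. Enlarging the ring instead gives no basis to expect any gain. Compound 4 is therefore estimated at 4.5 mg/kg, within 1.5 mg/kg to 15 mg/kg. The step this implies is expected to be a step that the limit leaves unreadable from compound 1 to compound 4.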

Compound 4, dose for half-maximal effect: > 3.16 mg/kg
Compound 4: only a limit was reported (the forecaster's own chance of this, stated with the estimate: 60%); the middle value is on the limit's open side.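

Compound 1 and compound 4 are both reported only as limits, and no step between them can be read: the limit of > 3.16 mg/kg in this assay, at which 2 of the 4 values shown sit.

The compounds shown leave open whether cyclohex-1-en-1-yl in place of cyclopent-1-en-1-yl changes the dose needed at all.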